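Methoxy addition on two related pyranone cores

The compounds below may be only part of what the source reports. "The series", "measured", "known", "first", "only" and "open" are said of these compounds alone.

This account concerns four compounds that share a styryl-type side chain on a six-membered aromatic ring bearing methoxy groups, attached to one of two cores. Compound 1 `COc1ccc(/C=C/C2CC(=O)C=CO2)cc1OC` and compound 2 `COc1cc(/C=C/C2CC(=O)C=CO2)cc(OC)c1OC` share one core; compound 3 `COc1ccc(/C=C/c2cc(=O)cco2)cc1` and compound 4 `COc1ccc(/C=C/c2cc(=O)cco2)cc1OC` share another. The difference between the two cores is not broken down here.

In a functional assay on U-251 cells (Homo sapiens) for inhibition, read by sulforhodamine B assay, with a stated time of 48 h (on this read-out higher numbers stand for weaker inhibition of growth and lower numbers for stronger inhibition of growth), compound 1 gives 86.9 uM. Compound 2 carries one more methoxy, the change being (methoxy in place of hydrogen on an aromatic carbon); the step of a 1.2-fold higher number from compound 1 to compound 2 (0.07 log units; within the scatter), so compound 2 gives 102 uM. In this assay compound 3 gives 278 uM, the highest of the three numbers, with its gap to both compound 2 and compound 1 beyond the scatter.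

Compound 4 is not yet measured. It differs from compound 3 by methoxy in place of hydrogen on an aromatic carbon. This is the same kind of change as that from compound 1 to compound 2, though the surroundings differ: in compound 2 the entering methoxy is also meta to a methoxy group, which is not so in compound 4. Resting on the step of a 1.2-fold higher number from compound 1 to compound 2 (0.07 log units; within the scatter), which stayed within the scatter, compound 4 is expected to sit close to compound 3, with an expected step of a 1.1-fold higher number from compound 3 to compound 4 (0.03 log units; within the scatter). The estimate for compound 4 in this assay is 300 uM, expected to lie between 120 uM and 700 uM.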

Compound 4, concentration for growth inhibition (reported as GI): 339 uM
Estimate against measurement, compound 4: 1.1-fold (0.05 log units) below; measured number inside the range.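

In this assay, methoxy in place of hydrogen on an aromatic carbon gives a 1.2-fold higher number from compound 3 to compound 4 (0.09 log units; within the scatter), and this step can be set beside the one seen on the other core: the same change on two cores in this assay, a 1.2-fold higher number (0.07 log units; within the scatter) from compound 1 to compound 2 and a 1.2-fold higher number (0.09 log units; within the scatter) from compound 3 to compound 4, 1.0-fold (0.02 log units) apart, within the scatter of two such steps. Within these four compounds, the change therefore carries from one core to the other as a small step on both, and the two steps give no sign that the cores respond differently. Among the compounds shown here, this does not show that the change is without effect on every member of the series or that the two cores would always behave alike, since it rests on only two pairs, the entering methoxy has different surroundings in each pair, and steps this small could hide a modest real difference.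

The compounds shown leave open whether an amine, a carboxylic acid or a fluorine atom at the same place on the aromatic ring, or a longer chain such as ethoxy or propoxy in place of the methoxy, would give a step that clears the scatter on either core. They also leave open whether the same small step would appear on other cell lines, since all of these numbers come from a single cell line.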